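The source may hold more compounds than are shown below. What is called first, only, known or untested is meant among the compounds shown, and "the series" means these compounds.

Measured in a functional assay on CCRF-CEM cells (Homo sapiens) for cytotoxicity, in the presence of a further agent that is not named here; a higher number here means a weaker inhibitor, a lower number a stronger inhibitor:
- compound 1 `Nc1nc(N)c(CCCNc2cc(F)ccc2[N+](=O)[O-])c(O)n1`: > 100000 nM
- compound 2 `COC(=O)c1ccc(CN(CCCc2c(N)nc(N)nc2O)c2cc(F)ccc2[N+](=O)[O-])cc1`: 30000 nM

Compound 1 gives only a limit, > 100000 nM, and no number.

Compound 3 `Nc1nc(N)c(CCCNc2cc(F)c(F)cc2[N+](=O)[O-])c(O)n1` differs from compound 1 as follows: fluoro in place of hydrogen on an aromatic carbon. This is fluoro in place of hydrogen on an aromatic carbon, ortho to a fluoro group.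

For the measured compounds named here, the only measured step, an at least 3.3-fold lower number from compound 1 to compound 2 (0.52 log units; beyond the scatter), is a substitution on a nitrogen, so it bears only loosely on this change. No step beyond the scatter is expected in this assay.

The expected step is a number no higher from compound 1 to compound 3 (the limit leaves the size open).

For compound 3 the estimate is 100000 nM, with an expected range of 30000 nM to 300000 nM.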

Compound 3, half-maximal inhibitory concentration: 97000 nM
Compound 3: the middle estimate sits 1.0-fold (0.01 log units) above what was measured; measured number inside the range.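

In this assay, fluoro in place of hydrogen on this aromatic carbon, ortho to a fluoro group, gives an at least 1.0-fold lower number from compound 1 to compound 3 (0.01 log units; that floor lies within the scatter). Compound 1 gives only a limit, > 100000 nM, so the change cannot be given a true size. Unlike the substitution on the nitrogen, this change shows no step beyond the scatter, and compound 3 gives 97000 nM. Compound 1 is the compound that sits at the limit: the limit of > 100000 nM in this assay, at which 1 of the 3 values shown sits.

Still open, from the compounds shown here alone, is whether an amine or a methoxy group on this carbon would shift the number. Also open, going by these compounds, is whether the added fluoro would count on the 4-(methoxycarbonyl)benzyl compound 2.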